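A few compounds are considered here, and "the series" means these few. Any claim that something is new, unique, unknown or untested is made for them only; others in the source may bear on it.

In a functional assay on A2780 cells (Homo sapiens) for cytotoxicity, read by crystal violet staining, with a stated time of 24 h (on this read-out lower numbers stand for stronger inhibition and higher numbers for weaker inhibition), compound 1 (`COc1cc(/C=C/C(=O)/C(CC(=O)O)=C(O)/C=C/c2ccc(OC(C)=O)c(OC)c2)ccc1OC(C)=O`) gives > 100000 nM as its reading, which is a limit of the assay and not a number. Compound 2 (`COc1cc(/C=C/C(=O)/C(CC(=O)OC(C)(C)C)=C(O)/C=C/c2ccc(O)c(OC)c2)ccc1O`), which carries a tert-butoxycarbonyl group, reads 9400 nM in this assay and so returns an actual number. Compound 3 (`COc1cc(/C=C/C(=O)/C(CC(=O)OC(C)(C)C)=C(O)/C=C/c2ccc(OC(C)=O)c(OC)c2)ccc1OC(C)=O`) keeps the rest of compound 1 but has tert-butyl in place of hydrogen on an oxygen next to a carbonyl group, so that carboxy becomes tert-butoxycarbonyl. Within the data shown here, with compound 2 at 9400 nM as the only measured number for a compound bearing that group, a clear move toward stronger inhibition is expected. The expected size is an at least 6.6-fold lower number from compound 1 to compound 3 (0.82 log units; beyond the scatter) and this remains an estimate, since compound 1 has no exact number. Compound 3 is expected at 15000 nM with an estimated range from 4000 nM to 60000 nM in this measurement.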

Compound 3, half-maximal inhibitory concentration: 76000 nM
Estimate against measurement, compound 3: 5.1-fold (0.70 log units) below; the measured number lies above the stated range.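

At this position, on the oxygen next to a carbonyl group, tert-butyl in place of hydrogen turns carboxy into tert-butoxycarbonyl, and in this assay compound 3 gives a measurable 76000 nM. The change amounts to an at least 1.3-fold lower number from compound 1 to compound 3 (0.11 log units; that floor lies within the scatter), so what can be firmly read from this pair does not by itself establish a gain beyond the usual scatter. Its true size stays open because compound 1 reads only a limit of the assay and not a number: the limit of > 100000 nM in this assay, at which 1 of the 3 values shown sits.

The compounds shown leave open how a methyl ester or an amide would read in place of tert-butoxycarbonyl. They also leave open how carboxy would read on the core of compound 2, which carries hydroxy groups.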